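The source may report more compounds than this note shows. Statements on the series, on what has been measured and on what is new or still open speak of the compounds shown alone.

Measured compounds:
- Compound 1 `Cc1c(-c2cc(Cl)cc(Cl)c2)c(C(=O)O)nn1-c1nc(-c2cc(Cl)cc(Cl)c2)c(SC(C)C)s1`: 2000 nM
- Compound 2 `CC(=O)Nc1ccc(-c2c(C)nn(-c3nc(-c4ccc(Cl)c(Cl)c4)c(SC(C)C)s3)c2C(=O)O)cc1`: 139000 nM
- Compound 3 `Cc1c(-c2cc(Cl)cc(Cl)c2)c(C(=O)O)nn1-c1nc(-c2ccc3nccn3c2)c(SC(C)C)s1`: "not active" (no number reported) (reported as a verdict, not as a number)

Three compounds sharing one core were tested in a functional assay on BJAB cells (Homo sapiens) for antiproliferative activity, with a stated time of 4 days; on this read-out lower numbers stand for an effect already at smaller amounts and higher numbers for an effect only at larger amounts of compound. Compound 1 gives 2000 nM, compound 2 gives 139000 nM, and compound 3 is reported simply as "not active" (no number reported) without a number. Of the two numbers shown, compound 2 stands at the highest, and the gap down to compound 1 lies beyond the usual scatter, so compound 1 acts at clearly smaller amounts than compound 2. No pair of these compounds differs in only one place, so no single change can be tied to that gap.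

Compound 4 `Cc1nn(-c2nc(-c3ccc(Cl)c(Cl)c3)c(SC(C)C)s2)c(C(=O)O)c1-c1cccc(F)c1` has not yet been measured. It differs from compound 2 in one place: 3-fluorophenyl in place of 4-acetamidophenyl on an aromatic carbon. Among the measured compounds, the two carrying a halogenated phenyl group on the pyrazole carbon sit at very different ends, so the direction of this change is uncertain. Compound 1 carries a halogenated phenyl at that position and gives 2000 nM, which suggests that a halogenated phenyl is compatible with an effect at smaller amounts. The step from compound 2 to compound 4 in this assay is therefore expected to be downward, a 9.3-fold lower number from compound 2 to compound 4 (0.97 log units; beyond the scatter), beyond the scatter. Compound 4 is estimated at 15000 nM, within a range from 3000 nM to 80000 nM.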

Compound 4, half-maximal effective concentration: 900 nM
Compound 4: the middle estimate sits 17-fold (1.22 log units) above what was measured; the measured number lies below the stated range.
By their numbers in this assay, from the lowest: compound 4; then compound 1; then compound 2.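

In this assay, replacing 4-acetamidophenyl with 3-fluorophenyl on the aromatic carbon next to the ring atom that bears a carboxy group gives a 150-fold lower number from compound 2 to compound 4 (2.19 log units; beyond the scatter). Among the compounds shown here, this is the first step here that ties a change in the read-out to a single place, and it shows that the group on this carbon can strongly shift the amount of compound needed, with the rest of the molecule held the same. None of the compounds shown offers a measured explanation for the size of this step.

The swap changes several things at once: the acetamido group leaves, a fluorine enters, and the substituent sits at a different place on the phenyl ring, so the step cannot be divided among these changes. A plain phenyl group, 4-fluorophenyl, 3-acetamidophenyl or 4-aminophenyl at this carbon would help separate them, and the compounds shown do not say whether the gain comes from losing the acetamido group, from adding the fluorine, or from both.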